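Methylating the hydroxyl of a chloropropanamide aniline

The source may hold more compounds than are shown below. What is called first, only, known or untested is meant among the compounds shown, and "the series" means these compounds.

For the measured compounds named here, in a functional assay on MCF7 cells (Homo sapiens) for antiproliferative activity, with a stated time of 48 h (on this read-out lower numbers stand for stronger inhibition and higher numbers for weaker inhibition), compound 1 `CCCCC(OC)c1cccc(NC(=O)NC(=O)CCl)c1` gives 6100 nM and compound 2 `CCCCC(OC)c1cccc(NC(=O)CCl)c1` gives 12000 nM; the move a 2.0-fold higher number from compound 1 to compound 2 (0.29 log units; within the scatter) is the only single-change step measured, and it alters a different part of the molecule. Compound 3 `CCCCC(O)c1cccc(NC(=O)CCCl)c1` reaches only the assay limit (the limit of > 100000 nM in this assay, at which 1 of the 3 values shown sits), so in this assay compound 3 shows > 100000 nM and no true number. Compound 4 `CCCCC(OC)c1cccc(NC(=O)CCCl)c1` is compound 3 with methyl in place of hydrogen on an oxygen on a saturated carbon, hydroxy to methoxy. Going by the values given here, no measured step covers this change, as compounds 1 and 2 carry the methoxy but differ from compound 4 elsewhere, so the expected step of an at least 1.6-fold lower number from compound 3 to compound 4 (0.22 log units; that floor lies within the scatter) rests on no precedent. Compound 4 is estimated at 60000 nM, within 15000 nM to 300000 nM, with a real chance that only a limit is reported again.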

Compound 4, half-maximal inhibitory concentration: > 100000 nM
Compound 4: only a limit was reported; the forecaster's own chance of this, stated with the estimate: 45%; middle value at least 1.6-fold (0.22 log units) away from the limit.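

Methoxy in place of hydroxy does not lift compound 4 off the limit where compound 3 already sits, so that step cannot be read: the limit of > 100000 nM in this assay, at which 2 of the 4 values shown sit.

The earlier compounds shown here did not show how much the group on the carbonyl matters among the methoxy compounds. Chloromethyl in place of chloro on a saturated chain carbon bound to a carbonyl carbon gives an at least 8.3-fold higher number from compound 2 to compound 4 (0.92 log units; beyond the scatter), and a different exchange of the group on the carbonyl carbon gives an at least 16-fold higher number from compound 1 to compound 4 (1.21 log units; beyond the scatter).

Going by these compounds, whether hydroxy and methoxy differ when the carbonyl group is that of compound 2 stays open. So does what an amine or a longer chain in place of the methoxy would do.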